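Flavone side-chain amines on A549: compound 3 expected

The source may report more compounds than this note shows. Statements on the series, on what has been measured and on what is new or still open speak of the compounds shown alone.

Measured compounds: compound 1 `COc1c(OCCCCNCc2ccccc2)cc(O)c2c(=O)cc(-c3ccccc3)oc12` with 4590 nM; compound 2 `CNCCOc1c(O)cc(O)c2c(=O)cc(-c3ccccc3)oc12` with "not determined" (no result reported), so no result is reported for it.

Among the measured compounds shown here, compound 1 holds the only number here in a functional assay on A549 cells (Homo sapiens) for cytotoxicity, read by MTT assay, with a stated time of 48 h (a higher number here means a weaker inhibitor, a lower number a stronger inhibitor), so it stands alone, with no comparison to draw. Compound 3 `COc1c(OCCCCN2CCN(C)CC2)cc(O)c2c(=O)cc(-c3ccccc3)oc12` differs from it by 4-methylpiperazin-1-yl in place of benzylamino on a saturated chain carbon, four bonds along the chain from an oxygen on an aromatic ring. For the measured compounds named here, no measured pair tells what such a change does, so the step is expected to be modest, likely a small weakening, from compound 1 to compound 3 a 1.4-fold higher number from compound 1 to compound 3 (0.15 log units; within the scatter). Compound 3 is therefore estimated at 6500 nM, within 2000 nM to 20000 nM.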

Compound 3, half-maximal inhibitory concentration: 1500 nM
Compound 3: middle estimate off by 4.3-fold (0.64 log units), on the high side; the measured number lies below the stated range.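

In this assay, 4-methylpiperazin-1-yl in place of benzylamino gives a 3.1-fold lower number from compound 1 to compound 3 (0.49 log units; beyond the scatter) and so lies beyond the usual scatter. This shows that the group on this saturated chain carbon, four bonds along the chain from an oxygen on an aromatic ring, can change the read-out, and that the benzene ring of benzylamino is not needed to keep a measurable value. No measurement given here accounts for the change.

From the compounds shown here alone, whether a morpholine or a piperidine ring would behave like 4-methylpiperazin-1-yl remains open. So does whether the step would hold on a shorter or longer chain.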